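The source may hold more compounds than are shown below. What is called first, only, known or untested is meant among the compounds shown, and "the series" means these compounds.

Measured so far:
compound 1, `CC(C)[C@H](C(=O)NC(C)(C)C)c1ccc(Cl)cc1`: < 30%
compound 2, `CC(C)C(C(=O)Nc1nc2ccccc2s1)c1ccc(Cl)cc1`: 91%

Both compounds were tested in a functional assay on CHO cells for agonist activity at Free fatty acid receptor 2 (Homo sapiens), read by cAMP accumulation; on this read-out lower numbers stand for smaller maximal responses and higher numbers for larger maximal responses. For compound 1 the assay gives only a limit, < 30%, and not a number; this is the situation described by the limit of < 30% in this assay, at which 1 of the 2 values shown sits. Compound 2, which also carries an aromatic group on the amide nitrogen, reaches 91% in this assay, so the two measured compounds sit far apart on this read-out.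

Compound 3, `CC(C)[C@H](C(=O)Nc1ncc(C#N)s1)c1ccc(Cl)cc1`, has not yet been measured. It differs from compound 1 in one place: 5-cyano-1,3-thiazol-2-yl in place of tert-butyl on an amide-type nitrogen. Going by the values given here, no step between two measured compounds is available for this exact change, so any expectation rests on the two values shown. Compound 2 with its aromatic amide substituent gives 91%. Compound 1, by contrast, has only a limit in this assay. A large upward step is therefore expected for compound 3, well beyond the usual scatter. The expected step is a number at least 45 percentage points higher from compound 1 to compound 3 (beyond the scatter). Compound 3 is therefore estimated to reach about 75% in this assay, with a plausible range from 40% to 100%.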

Compound 3, largest response reached (reported as efficacy), in percent of the reference or control that the assay uses: 105%
Compound 3: the middle estimate sits 30 percentage points below what was measured; the whole stated range lies below it.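

In this assay compound 1 gives < 30%, which is a limit of the assay and not a number. Going by these compounds alone, the earlier values offered no step for a change in one place, but here, with the rest of the molecule kept the same, placing 5-cyano-1,3-thiazol-2-yl instead of tert-butyl on the amide-type nitrogen gives a number at least 75 percentage points higher from compound 1 to compound 3 (beyond the scatter), so the group at this position can decide between a small and a large maximal response. The step is a minimum and its true size cannot be read because compound 1 has no exact value: the limit of < 30% in this assay, at which 1 of the 3 values shown sits.

The change swaps a whole group, so the compounds shown leave open whether the step comes from the five-membered ring, from the nitrile on it, or from both, and a plain thiazol-2-yl group, a phenyl group, or a thiazole carrying a carboxylic acid or an amine instead of the nitrile would help to separate these. On these data alone, this read-out also reports only the largest response reached, so how much compound each response requires remains open.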